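The source may hold more compounds than are shown below. What is called first, only, known or untested is meant among the compounds shown, and "the series" means these compounds.

Measured compounds:
Compound 1, `COc1cc2c(Oc3ccc(NC(=O)c4cn(-c5c(C)cccc5C)nn4)cc3F)ccnc2cc1OCCCN1CCCCC1`, gives 3520 nM in a functional assay on NCI-H460 cells (Homo sapiens) for cytotoxicity, read by MTT assay, with a stated time of 72 h; on this read-out lower numbers stand for stronger inhibition and higher numbers for weaker inhibition.
Compound 2, `COc1cc2c(Oc3ccc(NC(=O)c4cn(-c5ccc(F)c(F)c5)nn4)cc3F)ccnc2cc1OCCCN1CCCCC1`, gives 250 nM.
Compound 3, `COc1cc2c(Oc3ccc(NC(=O)c4cn(-c5c(C)cccc5C)nn4)cc3F)ccnc2cc1OCCCN1CCN(C)CC1`, gives 4540 nM.

Compounds 1 and 2 differ by one change, (3,4-difluorophenyl in place of 2,6-dimethylphenyl on an aromatic nitrogen). That change made the step of a 14-fold lower number from compound 1 to compound 2 (1.15 log units; beyond the scatter). Compounds 1 and 3 differ in their cores, as counted in 4-methylpiperazin-1-yl in place of piperidin-1-yl on a saturated chain carbon, three bonds along the chain from an oxygen on an aromatic ring, and this gave the step of a 1.3-fold higher number from compound 1 to compound 3 (0.11 log units; within the scatter), so the two cores sit within the usual scatter of each other in this assay. Compound 3 stands with the highest number of the three, but its nearest neighbour is compound 1, within the scatter.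

Compound 4, `COc1cc2c(Oc3ccc(NC(=O)c4cn(-c5ccc(F)c(F)c5)nn4)cc3F)ccnc2cc1OCCCN1CCN(C)CC1`, has not been measured in this assay. It differs from compound 3 by 3,4-difluorophenyl in place of 2,6-dimethylphenyl on an aromatic nitrogen, the same change that turns compound 1 into compound 2, made here on the core of compound 3; the place of the change is described in the same words in both pairs. Because the step of a 14-fold lower number from compound 1 to compound 2 (1.15 log units; beyond the scatter) is large and beyond the scatter, and because the core exchange a 1.3-fold higher number from compound 1 to compound 3 (0.11 log units; within the scatter) stays within the scatter, a step of similar size is expected from compound 3 to compound 4, namely a 14-fold lower number from compound 3 to compound 4 (1.15 log units; beyond the scatter). On that basis compound 4 is estimated to give 320 nM in this assay, with a range from 120 nM to 900 nM.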

Compound 4, half-maximal inhibitory concentration: 250 nM
Compound 4: the middle estimate sits 1.3-fold (0.11 log units) above what was measured; low and high end bracket the measured number.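

In this assay, putting 3,4-difluorophenyl in place of 2,6-dimethylphenyl on the aromatic nitrogen gave an 18-fold lower number from compound 3 to compound 4 (1.26 log units; beyond the scatter), and this step on the 4-methylpiperazin-1-yl compounds agrees with the one seen on the piperidin-1-yl compounds: the same change on two cores in this assay, a 14-fold lower number (1.15 log units; beyond the scatter) from compound 1 to compound 2 and an 18-fold lower number (1.26 log units; beyond the scatter) from compound 3 to compound 4, 1.3-fold (0.11 log units) apart, within the scatter of two such steps. Read the other way, with 3,4-difluorophenyl in place, 4-methylpiperazin-1-yl in place of piperidin-1-yl gave no change at the digits printed from compound 2 to compound 4 (within the scatter), and this exchange leaves the number within the scatter on both aryl groups: the same change on two cores in this assay, a 1.3-fold higher number (0.11 log units; within the scatter) from compound 1 to compound 3 and no change at the digits printed (within the scatter) from compound 2 to compound 4, 1.3-fold (0.11 log units) apart, within the scatter of two such steps. Together the four compounds show that the two changes behaved independently in this one cell assay, but they cover only two groups at each of two places, so they do not show that the aryl step would hold on any other core, and they do not explain why it is so large.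

The compounds shown leave open which of the two fluorines carries the step, since neither 3-fluorophenyl nor 4-fluorophenyl appears among them, and how an unsubstituted phenyl would compare. They also leave open whether the aryl step would persist with a morpholin-4-yl group or a shorter chain at the other end of the molecule.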